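Swapping Cyano for Acetamido in a Cytotoxicity Series

This account rests on a few compounds, and the source may have more. Where it says the series, first, only, none or still open, it means among the compounds named here.

Compound 1 `N#Cc1ccc(S(=O)(=O)N2C/C(=C\c3cccc(F)c3)C(=O)/C(=C/c3cccc(F)c3)C2)cc1`: 2600 nM
Compound 2 `CC(=O)Nc1ccc(S(=O)(=O)N2C/C(=C\c3cccc(F)c3)C(=O)/C(=C/c3cccc(F)c3)C2)cc1`: 11100 nM
Compound 3 `N#Cc1ccc(S(=O)(=O)N2C/C(=C\c3ccc(F)cc3)C(=O)/C(=C/c3ccc(F)cc3)C2)cc1`: 9800 nM

All three numbers come from a functional assay on HepG2 cells (Homo sapiens) for cytotoxicity, read by MTT assay, with a stated time of 24 h; on this read-out higher numbers stand for weaker inhibition and lower numbers for stronger inhibition. Compound 1 and compound 2 share one core and differ in one place only: acetamido in place of cyano on an aromatic carbon. That single change produced the step of a 4.3-fold higher number from compound 1 to compound 2 (0.63 log units; beyond the scatter), which is beyond the scatter of repeated runs, so the compound carrying the acetamido group is the weaker of the two.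

Compound 3 is built on a different core; how the two cores differ is not broken down here. Compound 3 and compound 2 give numbers that lie within the scatter of each other, so no order between them can be claimed.

Compound 4 `CC(=O)Nc1ccc(S(=O)(=O)N2C/C(=C\c3ccc(F)cc3)C(=O)/C(=C/c3ccc(F)cc3)C2)cc1` has not yet been measured. It stands to compound 3 exactly as compound 2 stands to compound 1: acetamido in place of cyano on an aromatic carbon. The place line is the same in both cases, so this is the same change, not merely the same kind. If it behaves as before, the step is expected to be a 3.9-fold higher number from compound 3 to compound 4 (0.59 log units; beyond the scatter), resting on the earlier step of a 4.3-fold higher number from compound 1 to compound 2 (0.63 log units; beyond the scatter). Compound 4 is therefore estimated at 38000 nM in this assay, expected to fall between 15000 nM and 95000 nM.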

Compound 4, half-maximal inhibitory concentration: 7400 nM
Estimate against measurement, compound 4: 5.1-fold (0.71 log units) above, and the stated range ends above it.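

On the core of compound 3, putting acetamido in place of cyano gives a 1.3-fold lower number from compound 3 to compound 4 (0.12 log units; within the scatter), so no order can be claimed between these two compounds. The same swap on the core of compound 1 had weakened inhibition clearly, which means that the change did not carry over from one core to the other in this assay: the same change on two cores in this assay, a 4.3-fold higher number (0.63 log units; beyond the scatter) from compound 1 to compound 2 and a 1.3-fold lower number (0.12 log units; within the scatter) from compound 3 to compound 4, 5.7-fold (0.75 log units) apart, beyond the scatter of two such steps. This shows that the effect of the swap depends on the core it is made on and that a step seen on one core cannot simply be transferred to the other, but two pairs of compounds do not explain why the steps differ, nor do they predict the outcome on any further core.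

From the compounds shown here alone, only cyano and acetamido appear at this position, so it remains open how an amine or a carboxylic acid on the same aromatic carbon would behave on either core. Going by these compounds, it also remains open whether such groups would show the same dependence on the core.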